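Extending the alkyl chain on compound 3's pyrimidine

The compounds below may be only part of what the source reports. "The series", "measured", "known", "first", "only" and "open" are said of these compounds alone.

Measured compounds:
compound 1 `CCCc1ncc(-c2nc(C(F)(F)F)sc2N2CCN(C(=O)Cn3cnc4cccnc43)[C@H](C)C2)cn1`: 33 nM
compound 2 `COc1ncc(-c2nc(C(F)(F)F)sc2N2CCN(C(=O)Cn3nc(C)nc3C)[C@H](C)C2)cn1`: 558 nM
compound 3 `CCc1ncc(-c2nc(C(F)(F)F)sc2N2CCN(C(=O)Cn3nc(C)nc3C)[C@H](C)C2)cn1`: 1430 nM

In a functional assay on U2OS cells for antagonist activity at C-X-C chemokine receptor type 3 (Homo sapiens), read by beta-arrestin recruitment (on this read-out lower numbers stand for stronger inhibition and higher numbers for weaker inhibition), compound 3 gives 1430 nM, the highest number of the three. Among the compounds with values here, its nearest neighbour is compound 2, and the step of a 2.6-fold higher number from compound 2 to compound 3 (0.41 log units; beyond the scatter) is the only single-point change among the measured compounds. Compound 1 gives 33 nM, far below compound 3, but it differs from compound 3 in two places, so the two values alone cannot be split between those changes.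

Compound 4 `CCCc1ncc(-c2nc(C(F)(F)F)sc2N2CCN(C(=O)Cn3nc(C)nc3C)[C@H](C)C2)cn1` is not yet measured. It differs from compound 3 by methyl in place of hydrogen on a saturated chain carbon, two bonds along the chain from an aromatic carbon. Within the data shown here, no measured step mirrors this change: the step from compound 2 to compound 3 concerns a different group at the same position, and compound 1 shares the propyl chain but carries a different acyl group. The expectation therefore rests on the observation that small changes at this position in this series have moved the number only modestly, as a 2.6-fold higher number from compound 2 to compound 3 (0.41 log units; beyond the scatter) shows.

Compound 4 is estimated at 1200 nM in this assay, with a range of 400 nM to 4000 nM. This estimate means a step of a 1.2-fold lower number from compound 3 to compound 4 (0.08 log units; within the scatter), expected to stay near the scatter in either direction.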

Compound 4, half-maximal inhibitory concentration: 258 nM
Compound 4: the middle estimate sits 4.7-fold (0.67 log units) above what was measured, outside the stated range (below it).
By their numbers in this assay, from the lowest: compound 1; then compound 4; then compound 2; then compound 3.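

In this assay, within the data shown here, lengthening ethyl to propyl gives a 5.5-fold lower number from compound 3 to compound 4 (0.74 log units; beyond the scatter), which shows that this chain is more sensitive to a single added carbon than the earlier compounds could reveal. Propyl also gives a lower number than methoxy at the same place, with a 2.2-fold lower number from compound 2 to compound 4 (0.34 log units; beyond the scatter), whereas ethyl gave a higher one, with a 2.6-fold higher number from compound 2 to compound 3 (0.41 log units; beyond the scatter), so one carbon reverses the order relative to methoxy. With propyl held fixed, the acyl group still matters, since the change to it gives a 7.8-fold higher number from compound 1 to compound 4 (0.89 log units; beyond the scatter), and the propyl chain alone therefore does not account for the low number of compound 1.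

As far as these compounds go, whether a butyl chain, an isopropyl group or a cyclopropyl ring here would lower the number further remains open, as does whether ethyl to propyl has the same effect with the acyl group of compound 1. Nothing available offers a reason for the size of these steps.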